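The source may report more compounds than this note shows. Statements on the series, on what has been measured and on what is new or still open speak of the compounds shown alone.

Values in a functional assay on K562 cells (Homo sapiens) for antiproliferative activity, read by sulforhodamine B assay, with a stated time of 48 h (on this read-out higher numbers stand for weaker inhibition and lower numbers for stronger inhibition), so far:
- compound 1 `CCc1cccc(NS(=O)(=O)c2ccc(N3CCNC3=O)cc2)c1` gives 230 nM
- compound 2 `Cc1ccc(C)c(NS(=O)(=O)c2ccc(N3CCNC3=O)cc2)c1` gives 72 nM
- compound 3 `COc1cccc(NS(=O)(=O)c2ccc(N3CCNC3=O)cc2)c1` is not yet measured

Among the measured compounds shown here, compound 1 holds the higher of the two numbers, and its nearest neighbour gives the only measured step, a 3.2-fold lower number from compound 1 to compound 2 (0.50 log units; beyond the scatter). The next change, to compound 3, puts methoxy in place of ethyl on an aromatic carbon, meta to a large group, counted as methoxy in place of ethyl on an aromatic carbon. The measured step is a different change, 2,5-dimethylphenyl in place of 3-ethylphenyl, so it offers only a rough size for changes on this ring. For the measured compounds named here, no measured pair carries a methoxy group, so no direction can be drawn from the data. The expected outcome in this assay is a 1.2-fold lower number from compound 1 to compound 3 (0.06 log units; within the scatter) and thus no move beyond the scatter. For compound 3 the estimated value is 200 nM with an expected range from 70 nM to 600 nM around it.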

Compound 3, half-maximal inhibitory concentration: 230 nM
For compound 3 the middle estimate is 1.2-fold (0.06 log units) below the measured one; measured number inside the range.
By their numbers in this assay, from the lowest: compound 2; then compounds 1 and 3 (each within the scatter of the next).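

In this assay, methoxy in place of ethyl on an aromatic carbon, meta to a large group, gives no change at the digits printed from compound 1 to compound 3 (within the scatter) and so leaves the read-out where it stood, even though the count of hydrogen-bond acceptors rises by the one on methoxy. The step to 3-methoxyphenyl in place of 2,5-dimethylphenyl gives a 3.2-fold higher number from compound 2 to compound 3 (0.50 log units; beyond the scatter) and matches in size the earlier 3.2-fold lower number from compound 1 to compound 2 (0.50 log units; beyond the scatter), so compound 1 and compound 3 both stand apart from compound 2 by the same margin. No measured evidence is available to account for these results.

Still open, going by these compounds, is how this position responds to groups of another kind, such as an amine, a carboxylic acid or a longer chain. Also open, on these data alone, is how methoxy reads when placed on the 2,5-dimethylphenyl ring of compound 2.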